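Swapping Ethyl for Acetyl on a Urea Side Chain

The compounds below may be only part of what the source reports. "The series", "measured", "known", "first", "only" and "open" are said of these compounds alone.

Measured so far in an ADME assay on the whole organism with Oryza sativa as the target, tested at 10 uM; on this read-out lower numbers stand for a stronger effect and higher numbers for a weaker effect at the one concentration tested:
Compound 1 `CCc1ccc(NC(=O)N[C@H](C)c2ccccc2)cc1` gives 44%.
Compound 2 `CCc1ccc(NC(=O)N[C@@H](C)c2ccccc2)cc1` gives 91%.
Compound 3 `CC(C)c1cccc(NC(=O)N[C@@H](C)c2ccccc2)c1` gives 86%.

Compound 2 stands highest of these three numbers, which here means the weakest effect at the single concentration tested. Compound 3 lies within the scatter of compound 2, so no order can be read between them, while compound 1 sits far lower. Among the measured compounds shown here, the only step between compounds that differ in one place is a number 47 percentage points higher from compound 1 to compound 2 (beyond the scatter), and it goes with the fact that compounds 1 and 2 differ only in the configuration as drawn.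

Compound 4 `CC(=O)c1ccc(NC(=O)N[C@@H](C)c2ccccc2)cc1` is the next compound. Compared with compound 2 it shows (acetyl in place of ethyl on an aromatic carbon). For the measured compounds named here, none of the measured steps involves this kind of change, so there is nothing to lean on for its direction. In the absence of any guide, a step of about a number 9 percentage points lower from compound 2 to compound 4 (within the scatter) is expected for compound 4, with a wide range. Compound 4 is estimated at 82%, between 55% and 100%.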

Compound 4, a percentage reported as activity, at one concentration (the size of the read-out at that concentration, not a potency): 96%
The estimate for compound 4 lay 14 percentage points below the measured number; the measured number falls inside the stated range.
By their numbers in this assay, from the lowest: compound 1; then compounds 3, 2 and 4 (each within the scatter of the next).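

In this assay, swapping ethyl for acetyl para to a large group gives a number 5 percentage points higher from compound 2 to compound 4 (within the scatter). At this position, then, the two groups cannot be told apart, even though acetyl brings a double bond outside the aromatic ring and a hydrogen-bond acceptor that ethyl lacks. Nothing known so far speaks to why these two groups read alike.

As far as these compounds go, this reading holds only for the configuration drawn in compound 2 and compound 4, so it remains open whether the same swap would also make no clear difference in the configuration of compound 1, which gives 44%. Also open, from the compounds shown here alone, is what an amine, a carboxylic acid or a longer chain would give at this same position.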